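Antiproliferative series: amine substitution on the amide side chain

A few compounds are considered here, and "the series" means these few. Any claim that something is new, unique, unknown or untested is made for them only; others in the source may bear on it.

Measured compounds in a functional assay on HeLa cells (Homo sapiens) for antiproliferative activity, read by MTT assay, with a stated time of 48 h; on this read-out lower numbers stand for stronger inhibition and higher numbers for weaker inhibition:

compound 1, `CCNCC(=O)Nc1cc(OC)ccc1C(=O)c1ccc(OC)c2c1C=CC(C)(C)O2`: compound 1 gives 4270 nM
compound 2, `CCNCC(=O)Nc1cc(OC)ccc1C(=O)c1ccc2c(c1)C=CC(C)(C)O2`: compound 2 gives 3110 nM
compound 3, `COc1ccc(C(=O)c2ccc(OC)c3c2C=CC(C)(C)O3)c(NC(=O)CN(C)C)c1`: compound 3 gives 3620 nM

The three values lie within the usual scatter of one another, so no order among compound 1, compound 2 and compound 3 can be read from them. Compound 3 differs from compound 1 by one change, (dimethylamino in place of ethylamino on a saturated chain carbon bound to a carbonyl carbon); in this assay that change gave a 1.2-fold lower number from compound 1 to compound 3 (0.07 log units; within the scatter), a step inside the scatter. Compound 2 and compound 1 differ in their cores; the difference between the two cores is not broken down here, and the gap between their values is in any case within the scatter.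

Compound 4, `COc1ccc(C(=O)c2ccc3c(c2)C=CC(C)(C)O3)c(NC(=O)CN(C)C)c1`, is not yet measured. It stands to compound 2 as compound 3 stands to compound 1: the change is dimethylamino in place of ethylamino on a saturated chain carbon bound to a carbonyl carbon, at the same place as before, so it is the same change made on the core of compound 2. Among the compounds with values here, with only one earlier instance, made on the core of compound 1, the expectation rests on that step alone: the step from compound 2 to compound 4 in this assay is estimated as a 1.2-fold lower number from compound 2 to compound 4 (0.06 log units; within the scatter), of the same small size as a 1.2-fold lower number from compound 1 to compound 3 (0.07 log units; within the scatter). Compound 4 is therefore expected to give about 2700 nM, with a plausible span from 1300 nM to 5600 nM.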

Compound 4, half-maximal inhibitory concentration: 1260 nM
Estimate against measurement, compound 4: 2.1-fold (0.33 log units) above; the measured number lies below the stated range.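

Dimethylamino in place of ethylamino gives a 2.5-fold lower number from compound 2 to compound 4 (0.39 log units; beyond the scatter) in this assay, a modest step that lies beyond the scatter, whereas the same change on the core of compound 1 stayed inside it. Set side by side, the two steps cannot be told apart: the same change on two cores in this assay, a 1.2-fold lower number (0.07 log units; within the scatter) from compound 1 to compound 3 and a 2.5-fold lower number (0.39 log units; beyond the scatter) from compound 2 to compound 4, 2.1-fold (0.32 log units) apart, within the scatter of two such steps. The result is therefore compatible with the change carrying from one core to the other at a similar size, but it does not show that the size is the same on both cores or that the core alters it, and two pairs set no rule for the series.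

Open, on these data alone, is whether a step of this size persists with other amines on the same saturated chain carbon, such as diethylamino, pyrrolidine or morpholine, or with a primary amine or a longer chain carrying the dimethylamino group. Also open, as far as these compounds go, is whether further pairs on these two cores would show the change to be of one size throughout or to depend on the core.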